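Aryl variation on the triazole nitrogen, HepG2 antiproliferative series

A few compounds are considered here, and "the series" means these few. Any claim that something is new, unique, unknown or untested is made for them only; others in the source may bear on it.

Measured so far:
- compound 1 `Cc1ccccc1-n1nncc1CN1C(=O)C2(C(C#N)=C(N)Oc3c2c2nc4ccccc4nc2c2ccccc32)c2ccccc21` gives a limit only in a functional assay on HepG2 cells (Homo sapiens) for antiproliferative activity, read by MTT assay, with a stated time of 48 h; on this read-out lower numbers stand for stronger inhibition and higher numbers for weaker inhibition: > 50000 nM
- compound 2 `N#CC1=C(N)Oc2c(N)cc3nc4ccccc4nc3c2C12C(=O)N(Cc1cnnn1-c1ccccc1Br)c1ccccc12` gives 38000 nM in this assay

Among the measured compounds shown here, compound 2 holds the only number in this assay; the other value is a limit, (the limit of > 50000 nM in this assay, at which 1 of the 2 values shown sits), and compound 1 therefore gives no number to set against it. Compound 3 `COc1cc(-n2nncc2CN2C(=O)C3(C(C#N)=C(N)Oc4c(N)cc5nc6ccccc6nc5c43)c3ccccc32)c(OC)cc1Cl` is the next entry. It differs from compound 2 in one place: 4-chloro-2,5-dimethoxyphenyl in place of 2-bromophenyl on an aromatic nitrogen. For the measured compounds named here, no pair of measured compounds shows what this kind of exchange does in this assay, so no measured step can be cited for it. With nothing to draw on, no step beyond the usual scatter is expected from compound 2 to compound 3, and the expected change is a 1.1-fold higher number from compound 2 to compound 3 (0.02 log units; within the scatter). Compound 3 is estimated to give 40000 nM in this assay, within a range from 15000 nM to 110000 nM, the upper end reaching where only a limit would be reported.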

Compound 3, half-maximal inhibitory concentration: > 50000 nM
Compound 3 gave a limit, no number; the forecaster's own chance of this, stated with the estimate: 40%; at least 1.2-fold (0.09 log units) between middle value and limit.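

In this assay, compound 3 gives only a limit, > 50000 nM. Among the compounds shown here, exchanging 2-bromophenyl for 4-chloro-2,5-dimethoxyphenyl on the aromatic nitrogen gives the first readable step at this position, an at least 1.3-fold higher number from compound 2 to compound 3 (0.11 log units; that floor lies within the scatter); this is a floor and not a size, so the true step may be larger or may not clear the scatter. The 4-chloro-2,5-dimethoxyphenyl group does not bring a measurable number, and the readings shown crowd at the top of the range: the limit of > 50000 nM in this assay, at which 2 of the 3 values shown sit.

For the compounds shown here, compound 2 remains the only number in this assay, so how far this position can move the read-out stays open. Also open, on these data alone, is whether a phenyl ring carrying an amine or a carboxylic acid, or a simple alkyl chain on this nitrogen, would give a number clear of the limit.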